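Bromine on a Five-Membered Ring: Expected Half-Life

The source may hold more compounds than are shown below. What is called first, only, known or untested is meant among the compounds shown, and "the series" means these compounds.

Three compounds built on a shared skeleton were tested in an ADME assay on microsomes from liver (Homo sapiens) for metabolic stability; on this read-out higher numbers stand for a longer-lived compound and lower numbers for a shorter-lived compound. Compound 3 `CCCNC(=O)C1CCN(C(=O)c2cc3ccccc3n2Cc2ccc(OC)cc2)CC1` gives 0.0443 h in this assay. Compound 2 `CCCNC(=O)C1CCN(C(=O)c2cc3cc(Br)ccc3n2Cc2ccc(OC)cc2)CC1` gives 0.0657 h in this assay; it differs from compound 3 by bromo in place of hydrogen on an aromatic carbon, and this gave a 1.5-fold higher number from compound 3 to compound 2 (0.17 log units; within the scatter). Compound 1 `CCCNC(=O)C1CCN(C(=O)c2cc3occc3n2Cc2ccc(OC)cc2)CC1` has a core that differs from the core of compound 3 in a way that is not broken down here; in this assay compound 1 gives 0.0457 h. Its value and that of compound 3 lie within the scatter of one another, and so do its value and that of compound 2.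

Compound 4 `CCCNC(=O)C1CCN(C(=O)c2cc3oc(Br)cc3n2Cc2ccc(OC)cc2)CC1` has not yet been measured. It differs from compound 1 by bromo in place of hydrogen on an aromatic carbon. Among the compounds with values here, this is the same kind of change as the one from compound 3 to compound 2, but not the same: there the bromo sits on a six-membered aromatic ring of carbon only, meta to a fused ring and para to a fused ring, whereas here it sits on a five-membered aromatic ring with 1 oxygen, next to the ring oxygen. Within the data shown here, the only guide available is the earlier step, which stayed within the scatter. Resting on the observation that the same kind of change gave a 1.5-fold higher number from compound 3 to compound 2 (0.17 log units; within the scatter), compound 4 is expected to show a 1.3-fold higher number from compound 1 to compound 4 (0.12 log units; within the scatter). The estimate for compound 4 in this assay is 0.06 h, with a likely range from 0.03 h to 0.12 h.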

Compound 4, half-life: 0.158 h
For compound 4 the middle estimate is 2.6-fold (0.42 log units) below the measured one, and the stated range ends below it.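

In this assay, putting bromo in place of hydrogen on an aromatic carbon of the core of compound 1 gave a 3.5-fold higher number from compound 1 to compound 4 (0.54 log units; beyond the scatter), so on this core the change produced a real rise in half-life, one larger than repeat measurements would be expected to produce by chance. Within the data shown here, although only this step lies beyond the scatter, the data do not show that the change behaves differently on the two cores, as the two steps cannot be told apart: the same change on two cores in this assay, a 1.5-fold higher number (0.17 log units; within the scatter) from compound 3 to compound 2 and a 3.5-fold higher number (0.54 log units; beyond the scatter) from compound 1 to compound 4, 2.3-fold (0.37 log units) apart, within the scatter of two such steps Nor do they show that the change carries over by a fixed amount, since this rests on only two pairs of compounds, with the bromo on a six-membered aromatic ring of carbon only in one pair and on a five-membered aromatic ring with 1 oxygen, next to the ring oxygen, in the other.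

The compounds shown leave open whether the rise in compound 4, at 0.158 h, is specific to bromo or would also appear with another group in the same place, such as chloro, methyl or a nitrile. They also leave open whether the step would keep its size if the propyl chain on the amide were replaced by a longer chain.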